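Swapping One Aminopyridine for Another on a Shared Core

This account rests on a few compounds, and the source may have more. Where it says the series, first, only, none or still open, it means among the compounds named here.

Three compounds share one core and differ only in the aromatic group attached to it. Compound 1 `O=C(O)Cc1sc(C(c2ccc(F)cc2)c2ccc(F)cc2)nc1-c1ccc(Cl)cc1` gives 9.7 nM in an in vitro assay on HEK385-7 cells for displacement of a labelled ligand from prostaglandin D2 receptor 2 (Homo sapiens); a higher number here means a weaker inhibitor, a lower number a stronger inhibitor. Compound 2 `O=C(O)Cc1sc(C(c2ccc(F)cc2)c2ccc(F)cc2)nc1-c1ccnc(F)c1` gives 0.48 nM, and compound 3 `CN(C)c1cc(-c2nc(C(c3ccc(F)cc3)c3ccc(F)cc3)sc2CC(=O)O)ccn1` gives 380 nM. Compound 3 therefore has the highest number of the three, that is, the weakest binding: a 39-fold higher number from compound 1 to compound 3 (1.59 log units; beyond the scatter), and a 790-fold higher number from compound 2 to compound 3 (2.90 log units; beyond the scatter).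

Compound 4 `Cc1cc(-c2nc(C(c3ccc(F)cc3)c3ccc(F)cc3)sc2CC(=O)O)cnc1N` differs from compound 3 in one place: 6-amino-5-methylpyridin-3-yl in place of 2-(dimethylamino)pyridin-4-yl on an aromatic carbon. Going by the values given here, no measured step matches this change exactly. Among the compounds with values here, the steps that bear on it are the two that lead into compound 3, both large and both ending at a much weaker number once a pyridine carrying a dimethylamino group entered. Compound 4 keeps an amino group on its pyridine, so its number is expected to remain in the weak range, with only a modest change; the expected step is a 1.5-fold lower number from compound 3 to compound 4 (0.18 log units; within the scatter). For compound 4 the estimate is 250 nM, within a range from 40 nM to 1500 nM.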

Compound 4, half-maximal inhibitory concentration: 880 nM
Compound 4: middle estimate off by 3.5-fold (0.55 log units), on the low side; the measured number falls inside the stated range.
By their numbers in this assay, from the lowest: compound 2; then compound 1; then compound 3; then compound 4.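

Changing the aminopyridine did not recover binding: the swap gave a 2.3-fold higher number from compound 3 to compound 4 (0.36 log units; beyond the scatter), even though the entering group carries a hydrogen-bond donor and the leaving group has none. The gaps to the other two groups are far larger, with a 1800-fold higher number from compound 2 to compound 4 (3.26 log units; beyond the scatter) and a 91-fold higher number from compound 1 to compound 4 (1.96 log units; beyond the scatter), which makes compound 4 the weakest binder of the four. At this ring carbon, both amino-bearing pyridines therefore bind much more weakly than the 2-fluoropyridin-4-yl and 4-chlorophenyl groups, and nothing available explains this gap.

Compound 4 differs from compound 3 in its amino group, its methyl group and the way its pyridine is attached, all at once, so the effect of each remains unresolved. A plain amino or a methoxy group in place of the fluoro of compound 2 would be a closer test of what the fluoro contributes.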